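From 2-Methoxyphenyl to 3-Methoxyphenyl: One Small Swap

The source may report more compounds than this note shows. Statements on the series, on what has been measured and on what is new or still open speak of the compounds shown alone.

Two related compounds have been tested so far in a functional assay on HepG2 cells (Homo sapiens) for inhibition, read by MTT assay, with a stated time of 24 h; a lower number here means a stronger inhibitor of growth, a higher number a weaker inhibitor of growth. There, compound 1 `COc1cccc(C(=O)n2c(-c3cn(C)c4ccccc34)nc3ccccc32)c1` gives 13600 nM, and compound 2 `COc1ccc2c(c1)c(-c1nc3ccccc3n1C(=O)c1ccccc1OC)cn2C` gives 23600 nM. These two numbers lie within the usual scatter of repeated measurements, so compound 2 cannot be separated from compound 1 on this evidence.

The next compound, compound 3 `COc1cccc(C(=O)n2c(-c3cn(C)c4ccc(OC)cc34)nc3ccccc32)c1`, has the same atoms as compound 2 but joined differently, with 3-methoxyphenyl in place of 2-methoxyphenyl on a carbonyl carbon. Within the data shown here, no pair of measured compounds shows this change on its own. Among the measured compounds shown here, the one guide is that compound 1 also carries 3-methoxyphenyl on a carbonyl carbon and gives 13600 nM. The expected result in this assay is therefore no shift beyond the scatter, with an estimated step of a 1.4-fold lower number from compound 2 to compound 3 (0.14 log units; within the scatter). For compound 3 the estimated value is 17000 nM, with an expected range of 7500 nM to 38000 nM.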

Compound 3, concentration for 50% growth inhibition: 11700 nM
Estimate against measurement, compound 3: 1.5-fold (0.16 log units) above; the range from low to high includes it.
By their numbers in this assay, from the lowest: compounds 3, 1 and 2 (each within the scatter of the next).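

In this assay the swap of 3-methoxyphenyl for 2-methoxyphenyl on a carbonyl carbon can now be read directly (a 2.0-fold lower number from compound 2 to compound 3 (0.30 log units; within the scatter)), and on this evidence it cannot be told apart from no effect. The second new pair gives a direct reading of methoxy in place of hydrogen on an aromatic carbon (a 1.2-fold lower number from compound 1 to compound 3 (0.07 log units; within the scatter)), and this change likewise shows no separable shift. Nothing measured here bears on why these numbers lie so close together.

So far, neither change has moved the number beyond the scatter, so neither place has been shown to matter in this assay. Still open, going by these compounds, is whether an amine or a carboxylic acid in place of the methoxy of 3-methoxyphenyl would give a clearly different number.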